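Swapping the Methylsulfanylphenyl for a Fused Heteroaryl

A few compounds are considered here, and "the series" means these few. Any claim that something is new, unique, unknown or untested is made for them only; others in the source may bear on it.

Three compounds of a shared core, a prolinamide joined by a chain to a piperazine that carries an aromatic group, have been tested in an assay on HEK293 cells for displacement of a labelled ligand from 5-hydroxytryptamine receptor 7 (Homo sapiens), with a stated time of 1 h; on this read-out higher numbers stand for weaker inhibition and lower numbers for stronger inhibition. Compound 1 `CSc1ccccc1N1CCN(CCCCC(=O)N2CCC[C@H]2C(N)=O)CC1` gives 163 nM, the lowest of the three numbers. Compound 3 `NC(=O)[C@@H]1CCCN1C(=O)CCCCCN1CCN(c2cccc(Cl)c2Cl)CC1` gives 179 nM, and this lies within the scatter of compound 1. Compound 2 `NC(=O)[C@@H]1CCCN1C(=O)CCCCCN1CCN(c2ccc(F)cc2)CC1` gives 1190 nM, which is beyond the scatter from compound 1, so compound 1 sits at the strong end of the set.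

Among the compounds with values here, the one step between measured compounds that differ in a single place is the change of the aromatic group on the piperazine: a 6.6-fold lower number from compound 2 to compound 3 (0.82 log units; beyond the scatter). It shows that this position can shift the read-out in this assay to a modest degree.

Compound 4 `NC(=O)[C@@H]1CCCN1C(=O)CCCCN1CCN(c2noc3ccccc23)CC1` has not yet been measured. It differs from compound 1 in the same position: a group of 9 heavy atoms (7 carbon, 1 nitrogen, 1 oxygen; one five-membered aromatic ring with 2 hetero atoms, one six-membered aromatic ring of carbon only) in place of a group of 8 heavy atoms (7 carbon, 1 sulfur; one six-membered aromatic ring of carbon only), on an amine nitrogen in a ring. Within the data shown here, no measured pair shows this particular swap, so the only guide is the size of the step from compound 2 to compound 3, which suggests that a change here may move the number moderately in either direction, or not beyond the scatter at all. For compound 4 the value in this assay is therefore expected to lie near that of compound 1, with the step of a 1.1-fold lower number from compound 1 to compound 4 (0.04 log units; within the scatter) as the estimate. The expected result for compound 4 is 150 nM, within a range from 40 nM to 600 nM.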

Compound 4, inhibition constant: 108 nM
Compound 4: the middle estimate sits 1.4-fold (0.14 log units) above what was measured; the measured number falls inside the stated range.
By their numbers in this assay, from the lowest: compounds 4, 1 and 3 (each within the scatter of the next); then compound 2.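

In this assay, the step is small: a 1.5-fold lower number from compound 1 to compound 4 (0.18 log units; within the scatter). Within the data shown here, the earlier step, a 6.6-fold lower number from compound 2 to compound 3 (0.82 log units; beyond the scatter), showed only that a swap at this place can move the number, whereas this pair shows that a very different group can go there without a shift beyond the scatter: 2-(methylsulfanyl)phenyl, a single six-membered ring holding sulfur, gives way to a two-ring group with a five-membered aromatic ring containing nitrogen and oxygen. The sulfur-bearing group is therefore not needed to keep the number at this level in this pair, although no data here explain why the two groups read alike.

From the compounds shown here alone, this rests on one pair, so it remains open whether other groups on the same amine nitrogen, such as a plain phenyl or a 2-methoxyphenyl, would also keep the number at this level. Going by these compounds, it is also open whether the group in compound 4 would hold this level on a longer chain, or with a carboxylic acid in place of the primary amide of the shared core.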